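The source may hold more compounds than are shown below. What is called first, only, known or untested is meant among the compounds shown, and "the series" means these compounds.

Compound 1 `Cn1ncnc1-c1ccccc1NCC1=NCCN1` and compound 2 `CCn1ncnc1-c1ccccc1NCC1=NCCN1` share one core, and in an in vitro functional assay on cells (Fibroblast) for agonist activity at Alpha-1D adrenergic receptor (Homo sapiens) (on this read-out lower numbers stand for an effect already at smaller amounts and higher numbers for an effect only at larger amounts of compound), compound 1 gives 63.1 nM while compound 2 gives 126 nM. The change between them is methyl in place of hydrogen on a saturated chain carbon bound to an aromatic nitrogen, and the step it made was a 2.0-fold higher number from compound 1 to compound 2 (0.30 log units; within the scatter). Compound 3 `CCn1nccc1-c1ccccc1NCC1=NCCN1` has a different core; the difference between the two cores is not broken down here. For compound 3 this assay gives only a limit, < 100000 nM, as noted in the limit of < 100000 nM in this assay, at which 1 of the 3 values shown sits. Compound 4 `CCCn1nccc1-c1ccccc1NCC1=NCCN1` carries the same kind of change as compound 2, namely (methyl in place of hydrogen on a saturated chain carbon, two bonds along the chain from an aromatic nitrogen), though its place lies two bonds along the chain from the aromatic nitrogen rather than bound to it. Since the earlier step stayed within the scatter, the step from compound 3 to compound 4 is expected to be a step that the limit leaves unreadable from compound 3 to compound 4, and compound 4 is estimated at 50000 nM in this assay, most likely again as a limit.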

Compound 4, half-maximal effective concentration: < 100000 nM
Compound 4 was reported as a limit; the forecaster's own chance of this, stated with the estimate: 70%; the middle value is on the limit's open side.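

Compound 3 and compound 4 are both reported only as limits in this assay, so no step can be read between them: the limit of < 100000 nM in this assay, at which 2 of the 4 values shown sit.

The compounds shown leave open whether the added methyl changes the effect on this core at all.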